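Replacing the dichlorophenyl of compound 1 with dimethoxyphenyl

This account rests on a few compounds, and the source may have more. Where it says the series, first, only, none or still open, it means among the compounds named here.

Measured compounds:
compound 1 `COc1cc(-c2cc(/C=C/C(=O)c3ccc(Cl)c(Cl)c3)[nH]n2)cc(OC)c1OC`: 16400 nM
compound 2 `COc1ccc(-c2cc(/C=C/C(=O)c3ccc(N)cc3)[nH]n2)cc1OC`: 3910 nM
compound 3 `COc1ccc(C(=O)/C=C/c2cc(-c3cc(OC)c(OC)c(OC)c3)n[nH]2)cc1`: 3020 nM

In a functional assay on LOX IMVI cells (Homo sapiens) for inhibition, read by sulforhodamine B assay, with a stated time of 48 h (on this read-out higher numbers stand for weaker inhibition of growth and lower numbers for stronger inhibition of growth), compound 1 gives the highest of the three numbers; compound 2 gives a value beyond the scatter below it, and compound 3 lies furthest below. Compound 4 `COc1ccc(C(=O)/C=C/c2cc(-c3cc(OC)c(OC)c(OC)c3)n[nH]2)cc1OC` has not yet been measured. It differs from compound 1 as follows: 3,4-dimethoxyphenyl in place of 3,4-dichlorophenyl on a carbonyl carbon. For the measured compounds named here, the one measured step that bears on this change is a 5.4-fold lower number from compound 1 to compound 3 (0.73 log units; beyond the scatter), where a methoxy-bearing phenyl also replaced the 3,4-dichlorophenyl on the carbonyl carbon. A step of similar size and direction is therefore expected in this assay, namely a 4.7-fold lower number from compound 1 to compound 4 (0.67 log units; beyond the scatter). Compound 4 is estimated at 3500 nM, with a likely range from 1200 nM to 10000 nM.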

Compound 4, concentration for total growth inhibition: 2760 nM
Beside the measured number, compound 4's estimate is 1.3-fold (0.10 log units) above it; the measured number falls inside the stated range.
By their numbers in this assay, from the lowest: compounds 4, 3 and 2 (each within the scatter of the next); then compound 1.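

In this assay, a second methoxy-bearing phenyl on the carbonyl carbon repeats what compound 3 showed: 3,4-dimethoxyphenyl in place of 3,4-dichlorophenyl gives (a 5.9-fold lower number from compound 1 to compound 4 (0.77 log units; beyond the scatter)). The extra methoxy in place of hydrogen on an aromatic carbon, however, leaves the two methoxy compounds indistinguishable (a 1.1-fold lower number from compound 3 to compound 4 (0.04 log units; within the scatter)). Nothing available explains either step.

Going by these compounds, it remains open whether losing the chlorines or gaining methoxy matters more, as an unsubstituted phenyl would test. Also open, on these data alone, is whether a longer ethoxy chain or a carboxylic acid there would match compound 4.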